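Amide variation on the carbonyl carbon of the shared core

The source may hold more compounds than are shown below. What is called first, only, known or untested is meant among the compounds shown, and "the series" means these compounds.

Measured so far:
compound 1, `CCC(C)NC(=O)/C=C/c1c(/C=C/c2ccc(OC)cc2)cc(OC)cc1OC`, 3950 nM
compound 2, `COc1ccc(/C=C/c2cc(OC)cc(OC)c2/C=C/C(=O)N2CCN(C)CC2)cc1`, 4510 nM
compound 3, `COc1ccc(/C=C/c2cc(OC)cc(OC)c2/C=C/C(=O)N2CCCCC2)cc1`, 10600 nM

Compound 3 gives the highest number of the three in a functional assay on A549 cells (Homo sapiens) for inhibition, read by MTT assay, with a stated time of 48 h; a higher number here means a weaker inhibitor, a lower number a stronger inhibitor; the nearer step up to it is a 2.4-fold higher number from compound 2 to compound 3 (0.37 log units; beyond the scatter) and the further one is a 2.7-fold higher number from compound 1 to compound 3 (0.43 log units; beyond the scatter), both beyond the scatter. Compound 4, `CCCCNC(=O)/C=C/c1c(/C=C/c2ccc(OC)cc2)cc(OC)cc1OC`, is not yet measured. The change from compound 3: butylamino in place of piperidin-1-yl on a carbonyl carbon. The step bearing on it is a 2.7-fold higher number from compound 1 to compound 3 (0.43 log units; beyond the scatter), where the open (sec-butyl)amino amide gave the lower number; the two ring-bearing amides, compound 2 and compound 3, both sit above compound 1. Running that step the other way, a modest decrease beyond the scatter is expected for compound 4, a 2.7-fold lower number from compound 3 to compound 4 (0.42 log units; beyond the scatter). Compound 4 is estimated at 4000 nM, range 2000 nM to 8000 nM.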

Compound 4, half-maximal inhibitory concentration: 1880 nM
Estimate against measurement, compound 4: 2.1-fold (0.33 log units) above, and the stated range ends above it.
By their numbers in this assay, from the lowest: compound 4; then compounds 1 and 2 (each within the scatter of the next); then compound 3.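

Open amide against ring amide on the carbonyl carbon now reads more sharply in this assay: butylamino gives a lower number than either ring-bearing amide (a 5.6-fold lower number from compound 3 to compound 4 (0.75 log units; beyond the scatter)) and (a 2.4-fold lower number from compound 2 to compound 4 (0.38 log units; beyond the scatter)). Among the open amides the chain also counts, since butyl in place of sec-butyl on the amide-type nitrogen gives a step beyond the scatter (a 2.1-fold lower number from compound 1 to compound 4 (0.32 log units; beyond the scatter)). No measurement shown here accounts for these steps.

As far as these compounds go, whether a longer chain such as hexylamino continues the fall remains open. So does the effect of a terminal amine on the butyl chain.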